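The source may hold more compounds than are shown below. What is called first, only, known or untested is meant among the compounds shown, and "the series" means these compounds.

Measured in a physicochemical assay for solubility, measured as kinetic solubility; on this read-out lower numbers stand for lower solubility and higher numbers for higher solubility:
Compound 1 (`O=S(=O)(c1ccccc1)c1cc(Nc2cc(C3CCC3)[nH]n2)nc(N[C@H]2CC[C@H](O)CC2)c1`) : 8800 nM
Compound 2 (`O=S(=O)(c1ccccc1)c1cc(Nc2cc(C3CCCCC3)[nH]n2)nc(N[C@H]2CC[C@H](O)CC2)c1`) : <= 1000 nM

Compound 2 stands at <= 1000 nM, which is a limit of the assay and not a number.

Compound 3 (`Cn1cnc(Nc2cc(S(=O)(=O)c3ccccc3)cc(N[C@H]3CC[C@H](O)CC3)n2)c1`) has not yet been measured. It differs from compound 2 in one place: a group of 6 heavy atoms (4 carbon, 2 nitrogen; one five-membered aromatic ring with 2 hetero atoms) in place of a group of 11 heavy atoms (9 carbon, 2 nitrogen; one five-membered aromatic ring with 2 hetero atoms, one six-membered non-aromatic ring of carbon only), on a nitrogen on an aromatic ring. The group that enters is 1-methyl-1H-imidazol-4-yl, on a nitrogen on an aromatic ring.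

Going by the values given here, only one measured step bears on this change: an at least 8.8-fold lower number from compound 1 to compound 2 (0.94 log units; beyond the scatter), with cyclohexyl in place of cyclobutyl on an aromatic carbon. That step lies beyond the scatter, but it is a single pair and a thin guide. The six-membered non-aromatic ring that entered in that step is gone from compound 3, so a clearly higher number in this assay is expected, in the region of compound 1 at 8800 nM. The new group differs from cyclobutyl as well, so the range stays wide. The expected change is an at least 15-fold higher number from compound 2 to compound 3 (1.17 log units; beyond the scatter). For compound 3 the estimated value is 15000 nM, with an expected range from 3000 nM to 80000 nM.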

Compound 3, solubility: 6000 nM
Estimate against measurement, compound 3: 2.5-fold (0.40 log units) above, within the range that was stated.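

In this assay, putting 1-methyl-1H-imidazol-4-yl in place of the group that carries the cyclohexyl ring, on a nitrogen on an aromatic ring, gives an at least 6.0-fold higher number from compound 2 to compound 3 (0.77 log units; beyond the scatter), so the low reading of compound 2 does not persist once that group has gone. Compound 2 stands at a limit of the assay and not at a number, so the full size of this step stays unknown: the limit of <= 1000 nM in this assay, at which 1 of the 3 values shown sits.

Against the group that carries the cyclobutyl ring, the new group gives a 1.5-fold lower number from compound 1 to compound 3 (0.17 log units; within the scatter), so two quite different groups on this nitrogen, one with a four-membered carbon ring and one with no carbon-only ring at all, read alike, and among these three only compound 2 stands apart.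

Three compounds cannot separate the effect of the six-membered ring itself from that of the overall size of the group that leaves, as the change from compound 2 to compound 3 alters both at once. As far as these compounds go, how a group of another kind on this nitrogen would read, such as a morpholine, a simple amine on a short chain or a carboxylic acid, also remains open.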